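The compounds below may be only part of what the source reports. "The series", "measured", "known", "first", "only" and "open" are said of these compounds alone.

Compound 2 `CCNc1nc(-c2ccccc2)nc2c1nnn2Cc1ccccc1Cl` gives the highest number of the three measured in an assay on isolated protein for binding affinity to adenosine receptor A1 (Bos taurus) (on this read-out lower numbers stand for stronger inhibition and higher numbers for weaker inhibition), with 463000000 nM. Compound 1 `FC(F)(F)c1ccccc1Cn1nnc2c(NC3CCCCC3)nc(-c3ccccc3)nc21` reaches 6800000 nM in this assay, and compound 3 `CCCCNc1nc(-c2ccccc2)nc2c1nnn2Cc1ccccc1C(F)(F)F` reaches 6500000 nM; the one single-point step among these, a 1.0-fold lower number from compound 1 to compound 3 (0.02 log units; within the scatter), is a change of the group on the aromatic nitrogen that leaves the number essentially where it was. Compound 4 `CCCCCCNc1nc(-c2ccccc2)nc2c1nnn2Cc1ccccc1Cl` has not yet been measured. It differs from compound 2 by butyl in place of hydrogen on a saturated chain carbon, two bonds along the chain from a nitrogen on an aromatic ring. Among the compounds with values here, no measured step changes the length of the chain on that nitrogen alone, so the only guidance is that compound 2, with its short ethylamino, stands far above compound 3, which carries a butylamino but also a different group on the benzyl ring. The step from compound 2 to compound 4 is therefore expected to lower the number, a 7.7-fold lower number from compound 2 to compound 4 (0.89 log units; beyond the scatter), though with wide uncertainty. Compound 4 is estimated at 60000000 nM in this assay, within a range from 6000000 nM to 500000000 nM.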

Compound 4, inhibition constant: 31000000 nM
Compound 4: middle estimate off by 1.9-fold (0.29 log units), on the high side, and the stated range covers the measured number.
By their numbers in this assay, from the lowest: compounds 3 and 1 (each within the scatter of the next); then compound 4; then compound 2.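

Going from ethylamino to hexylamino with nothing else changed gives a 15-fold lower number from compound 2 to compound 4 (1.17 log units; beyond the scatter) in this assay, so the length of the chain on this aromatic nitrogen can move the number well beyond the scatter. The earlier single-point change at this nitrogen, butyl in place of cyclohexyl, gave only a 1.0-fold lower number from compound 1 to compound 3 (0.02 log units; within the scatter) and so showed no such sensitivity to the group placed there. Nothing available here accounts for the size of the new step.

The two chain lengths compared in one series cannot show whether the number falls steadily with each added carbon or mostly at one length, and an intermediate butyl or a longer octyl chain on this nitrogen would be needed to tell. On these data alone, it also remains open whether the same lengthening gives a step of similar size when the benzyl ring carries trifluoromethyl instead of chlorine.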